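The source may report more compounds than this note shows. Statements on the series, on what has been measured and on what is new or still open speak of the compounds shown alone.

Measured so far in an ADME assay on HEp-2 cells (Homo sapiens) for cytotoxicity, read by CCK-8 assay, with a stated time of 5 days; on this read-out higher numbers stand for lower toxicity in this test and lower numbers for higher toxicity in this test:
compound 1 `NCCNc1cc(N2CCCc3ccccc3C2)nc2ccc(F)cc12` — 8000 nM
compound 2 `CNCCNc1cc(N2CCCc3ccc(F)cc3C2)nc2ccc(C)cc12` — 29000 nM

Two compounds of the series have numbers in this assay. Compound 1 gives 8000 nM. Compound 2 gives 29000 nM, which is the highest of the two numbers; its gap to compound 1 lies beyond the scatter. Among the compounds with values here, the two differ from each other in more than one place, so the gap cannot be assigned to any single change, and no isolated step between measured compounds is available.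

Compound 3 `Cc1ccc2nc(N3CCCc4ccc(F)cc4C3)cc(NCCNC3COC3)c2c1` has not yet been measured in this assay. It differs from compound 2 in one place: oxetan-3-yl in place of methyl on an amine nitrogen. The place is an amine nitrogen whose other neighbour is a saturated chain carbon.

Without a measured pair that isolates this kind of change, the step of a 1.0-fold higher number from compound 2 to compound 3 (0.01 log units; within the scatter) from compound 2 is expected to be small, not beyond the scatter, with no clear direction. Compound 3 is therefore estimated at 30000 nM in this assay, with a range from 12000 nM to 75000 nM.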

Compound 3, half-maximal cytotoxic concentration: > 100000 nM
Compound 3 ended at the assay's limit (the forecaster's own chance of this, stated with the estimate: 20%); at least 3.3-fold (0.52 log units) between middle value and limit.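

Oxetan-3-yl in place of methyl on an amine nitrogen whose other neighbour is a saturated chain carbon gives the first single-place step of the series in this assay, and this step, an at least 3.4-fold higher number from compound 2 to compound 3 (0.53 log units; beyond the scatter), lies beyond the scatter towards lower toxicity in this test. The gap between compound 1 and compound 2 could not be assigned to any one change, whereas this pair shows that the group on this nitrogen alone can move the number. In this assay, going by these compounds, compound 3 gives > 100000 nM, which is a limit of the assay and not a number, so the step fixes only a lower bound on the size of this change and the true size stays unknown: the limit of > 100000 nM in this assay, at which 1 of the 3 values shown sits.

Cyclobutyl on the same nitrogen would show whether the step follows the four-membered ring or its oxygen, and an isopropyl or a longer chain would show whether carbon count alone moves the number. Within the data shown here, whether oxetan-3-yl acts in the same way on the core of compound 1 stays open, since the series so far offers this one pair for the change.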